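Urea series on the shared core: toward a methoxyphenyl analogue

This account rests on a few compounds, and the source may have more. Where it says the series, first, only, none or still open, it means among the compounds named here.

Three ureas built on the same core have been tested so far in a functional assay on T-24 cells (Homo sapiens) for antiproliferative activity, read by MTT assay, with a stated time of 48 h; a higher number here means a weaker inhibitor, a lower number a stronger inhibitor. Compound 1 `O=C(Nc1cccc(CNc2nccnc2Cl)c1)Nc1cccc2ccccc12` carries a naphthyl group on the urea; in this assay compound 1 reaches only the limit > 40000 nM, which is a boundary of the assay rather than a number. Compound 2 `O=C(Nc1cccc(CNc2nccnc2Cl)c1)Nc1ccc(Cl)cc1Br`, with a 2-bromo-4-chlorophenyl group on the urea, gives 6650 nM in this assay. Compound 3 `CCc1ccc(NC(=O)Nc2cccc(CNc3nccnc3Cl)c2)c(CC)c1` gives 6390 nM in this assay, and the two numbers of compound 2 and compound 3 sit within the usual scatter of each other, so the two measured numbers cannot be told apart. Compound 1 is known only by its limit (the limit of > 40000 nM in this assay, at which 1 of the 3 values shown sits).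

Compound 4 `COc1ccc(NC(=O)Nc2cccc(CNc3nccnc3Cl)c2)cc1` has not yet been measured. It differs from compound 2 in one place: 4-methoxyphenyl in place of 2-bromo-4-chlorophenyl on an amide-type nitrogen. Among the compounds with values here, no measured pair in this set isolates a change of this kind, so the size of the step is open. Given that compound 2 gives 6650 nM and that the series as a whole sits at weak potency, the author expects compound 4 to land close to compound 2 or somewhat weaker, with a step of a 1.8-fold higher number from compound 2 to compound 4 (0.26 log units; within the scatter). The estimate for compound 4 is therefore 12000 nM, within a range from 4000 nM to 40000 nM.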

Compound 4, half-maximal inhibitory concentration: 9820 nM
For compound 4 the middle estimate is 1.2-fold (0.09 log units) above the measured one; the range from low to high includes it.
By their numbers in this assay, from the lowest: compounds 3, 2 and 4 (each within the scatter of the next). At a limit, above all of these: compound 1.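

Within the data shown here, the first measured step in the set that isolates one place appears here: in this assay, 4-methoxyphenyl in place of 2-bromo-4-chlorophenyl on an amide-type nitrogen gives a 1.5-fold higher number from compound 2 to compound 4 (0.17 log units; within the scatter). The position therefore tolerates the loss of both the bromine and the chlorine and the arrival of a methoxy group, with the count of heavy atoms unchanged, without a step that can be told from the scatter. Nothing in the data gives a reason for the size of this step.

The compounds shown leave open whether any group on this nitrogen can move the number beyond the scatter in either direction, since this single step stays within it and says nothing about an unsubstituted phenyl, a phenyl ring bearing a carboxylic acid or a dimethylamino group, or a longer alkyl chain in place of the ring. They also leave open how far the naphthyl group of compound 1 really lies from the other groups, as compound 1 is known only by a limit of the assay.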